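The source may hold more compounds than are shown below. What is called first, only, known or untested is meant among the compounds shown, and "the series" means these compounds.

Values in an ADME assay on L132 cells (Homo sapiens) for cytotoxicity, read by MTT assay, with a stated time of 48 h; on this read-out higher numbers stand for weaker inhibition and lower numbers for stronger inhibition (each one a limit):
- compound 1 (`COc1ccccc1-n1cc(COC(=O)/C(C)=C/CC/C(C)=C/CC/C(C)=C/CC[C@@H]2[C@@]3(C)CCC(=O)C(C)(C)[C@H]3CC[C@@]2(C)O)nn1`): (> 150000 nM)
- compound 2 (`C/C(=C\CC/C(C)=C/CC[C@@H]1[C@@]2(C)CCC(=O)C(C)(C)[C@H]2CC[C@@]1(C)O)CC/C=C(\C)C(=O)OCc1cn(-c2ccc(C(F)(F)F)cc2)nn1`): (> 150000 nM)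
- compound 3 (`C/C(=C\CC/C(C)=C/CC[C@@H]1[C@@]2(C)CCC(=O)C(C)(C)[C@H]2CC[C@@]1(C)O)CC/C=C(\C)C(=O)OCc1cn(-c2ccccc2Br)nn1`): (> 150000 nM)

Compound 3 gives only a limit (> 150000 nM) and has no number of its own. The two other values are limits as well.

The change to compound 4 (`C/C(=C\CC/C(C)=C/CC[C@@H]1[C@@]2(C)CCC(=O)C(C)(C)[C@H]2CC[C@@]1(C)O)CC/C=C(\C)C(=O)OCc1cn(-c2cccc(C)c2)nn1`) puts 3-methylphenyl in place of 2-bromophenyl on an aromatic nitrogen.

The measured steps bear on it, but none has a readable size: (a step that the two limits leave unreadable from compound 1 to compound 2), (a step that the two limits leave unreadable from compound 1 to compound 3) and (a step that the two limits leave unreadable from compound 2 to compound 3). All three compounds sit at one limit (the limit of > 150000 nM in this assay, at which 3 of the 3 values shown sit).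

No step beyond the scatter and no direction is therefore expected in this assay for this change. The expected step is (a number no higher from compound 3 to compound 4 (the limit leaves the size open)). Compound 4 is expected at (150000 nM), with an estimated range from (80000 nM) to (300000 nM).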

Compound 4, half-maximal inhibitory concentration: > 150000 nM
Compound 4 was reported as a limit; the forecaster's own chance of this, stated with the estimate: 85%; the middle value sits exactly at the limit.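

In this assay compound 4 gives > 150000 nM, which is a limit, so no step linking compound 1, compound 2, compound 3 and compound 4 can be read: the limit of > 150000 nM in this assay, at which 4 of the 4 values shown sit.

From the compounds shown here alone, whether any group on the aromatic nitrogen gives a measurable half-maximal inhibitory concentration remains open.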